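The source may report more compounds than this note shows. Statements on the series, on what has been measured and on what is new or still open speak of the compounds shown alone.

The series rests on compound 1 `CCCCCCc1ccc(NC(=O)c2cc([N+](=O)[O-])ccc2F)cc1` and compound 2 `CCCCCCc1ccc(NC(=O)c2cc([N+](=O)[O-])ccc2Cl)cc1`; in an ADME assay on HepG2 cells (Homo sapiens) for cytotoxicity, with a stated time of 72 h (a lower number here means a stronger inhibitor, a higher number a weaker inhibitor), compound 1 gives 2500 nM. For compound 2 the read-out is a limit of the assay, > 50000 nM, so compound 2 stands at the limit of > 50000 nM in this assay, at which 1 of the 2 values shown sits. Going by the values given here, the single measured step, an at least 20-fold higher number from compound 1 to compound 2 (1.30 log units; beyond the scatter), carries compound 2 onto that limit. Compound 3 `COc1ccc(NC(=O)c2cc([N+](=O)[O-])ccc2Cl)cc1` differs from compound 2 by methoxy in place of hexyl on an aromatic carbon, set on an aromatic carbon of a six-membered aromatic ring of carbon only, para to a large group. Among the compounds with values here, no measured step touches this methoxy-for-hexyl exchange; the only step known concerns the halogen. With compound 2 already at a limit, compound 3 is expected to sit likewise, the step of a number no higher from compound 2 to compound 3 (the limit leaves the size open) being expected as none beyond the scatter in this assay. Compound 3 is therefore estimated at 50000 nM, within 20000 nM to 120000 nM, most likely reported again only as a limit.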

Compound 3, half-maximal inhibitory concentration: > 50000 nM
Compound 3: only a limit was reported; the forecaster's own chance of this, stated with the estimate: 70%; the middle value lies on the limit itself.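

Compound 2 and compound 3 both give only a limit in this assay, so no step between them can be read: the limit of > 50000 nM in this assay, at which 2 of the 3 values shown sit.

The compounds shown leave open what methoxy in place of hexyl does to this read-out, and how far past the limit either compound lies.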